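The compounds below may be only part of what the source reports. "The series", "measured", "known", "first", "only" and "open" are said of these compounds alone.

Measured compounds in a functional assay on 3T3-L1 cells (Mus musculus) for inhibition, with a stated time of 20 min, tested at 20 uM; on this read-out lower numbers stand for less inhibition and higher numbers for more inhibition at the one concentration tested (going by the name of the read-out):
- compound 1 `Cc1ccc(S(=O)(=O)n2cc(CN(Cc3cn(Cc4ccccc4)nn3)S(=O)(=O)c3ccccc3)c3ccccc32)cc1` gives -18%
- compound 2 `Cc1ccc(S(=O)(=O)n2cc(CN(Cc3ccccc3)Cc3cccc(F)c3F)c3ccccc32)cc1` gives -13.1%
- compound 3 `Cc1ccc(S(=O)(=O)n2cc(CN(Cc3cn(Cc4ccc(F)cc4)nn3)S(=O)(=O)c3ccccc3)c3ccccc32)cc1` gives -21%

All three numbers are negative at the single concentration tested; the differences between them fall inside the usual scatter of repeated measurements, so the three numbers in this assay are level with one another. Compound 1 sits between the other two, with compound 3 nearest and compound 2 furthest away.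

Compound 4 `Cc1ccc(S(=O)(=O)N(Cc2cn(Cc3ccccc3)nn2)Cc2cn(S(=O)(=O)c3ccc(C)cc3)c3ccccc23)cc1` differs from compound 1 in one spot: methyl in place of hydrogen on an aromatic carbon. The change sits on an aromatic carbon of a six-membered aromatic ring of carbon only, where the ring is attached to the sulfonyl group.

Among the compounds with values here, the only measured step of a similar kind is a number 3 percentage points lower from compound 1 to compound 3 (within the scatter). A small change on an aromatic ring thus left the read-out unchanged within the scatter. On that basis compound 4 is expected to show no shift beyond the scatter, a number 1 percentage points higher from compound 1 to compound 4 (within the scatter). The estimate for compound 4 is -17%, with a range from -30% to -4%.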

Compound 4, a percentage reported as inhibition, at one concentration (the size of the read-out at that concentration, not a potency): 3.4%
Beside the measured number, compound 4's estimate is 20.4 percentage points below it; measured number above the stated range.
By their numbers in this assay, from the lowest: compounds 3, 1 and 2 (each within the scatter of the next); then compound 4.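

In this assay, phenylsulfonyl to (4-methylphenyl)sulfonyl gives a number 21.4 percentage points higher from compound 1 to compound 4 (beyond the scatter), so this ring position, unlike the fluoro change on a different ring, moves the read-out beyond the scatter with only one added carbon. Compound 4 gives 3.4%, the only number above zero among the compounds shown, while the others are all negative. Nothing measured here explains how a single methyl at this position produces such a shift.

The compounds shown leave open whether the shift is particular to methyl or would also appear with another group at the same position, such as chlorine, methoxy or an amine. With only one concentration tested, they also leave open how the read-out of compound 4 would change at other concentrations.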